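The compounds below may be only part of what the source reports. "The series", "measured", "known", "first", "only" and "open" are said of these compounds alone.

Compound 1 `c1cc2c(C3CCNCC3)c[nH]c2cc1Nc1ccc2c(C3CCNCC3)c[nH]c2c1`: 89%
Compound 2 `Fc1ccc(Nc2ccc3c(C4CCNCC4)c[nH]c3c2)cc1F`: 89%

Level with compound 1 within the scatter, compound 2 stands at 89% in an ADME assay on microsomes from liver (Homo sapiens) for metabolic stability, with a stated time of 1 h; on this read-out higher numbers stand for a more stable compound and lower numbers for a less stable compound. The next structure, compound 3 `Cn1cc(C2CCNCC2)c2ccc(Nc3ccc(F)c(F)c3)cc21`, differs from compound 2 by methyl in place of hydrogen on an aromatic nitrogen, with methyl in place of hydrogen on an aromatic nitrogen. Going by the values given here, no measured pair shows what such a change does, so the expectation is tentative: a small downward step in this assay, of about the size of the scatter. The expected step is a number 9 percentage points lower from compound 2 to compound 3 (within the scatter). For compound 3 the estimated value is 80%, within an expected range of 62% to 93%.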

Compound 3, percent of the compound remaining in the liver assay: 77%
The estimate for compound 3 lay 3 percentage points above the measured number, and the stated range covers the measured number.
By their numbers in the liver assay, from the lowest: compound 3; then compounds 1 and 2 (each within the scatter of the next).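

Going by these compounds alone, in the liver assay, compound 2 gives 89% and compound 3 gives 77%; methyl in place of hydrogen on the aromatic nitrogen gives a number 12 percentage points lower from compound 2 to compound 3 (beyond the scatter), the first measured change at this position and thus the first sign that the position bears on this read-out. In a physicochemical assay for solubility, in phosphate buffer, at pH 7.4 (a higher number here means a more soluble compound, a lower number a less soluble compound), compound 2 gives 178000 nM and compound 3 gives 169000 nM; the same change gives a 1.1-fold lower number from compound 2 to compound 3 (0.02 log units; within the scatter), so the two read-outs do not move together here. Nothing measured explains this drop.

From the compounds shown here alone, it remains open whether ethyl, a longer chain or an acetyl group on this nitrogen would give a smaller or larger step in the liver assay.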